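Notes on one substituent swap on the shared core

This account rests on a few compounds, and the source may have more. Where it says the series, first, only, none or still open, it means among the compounds named here.

- compound 1 `CCc1ccc(N(CC(C)C)S(=O)(=O)c2ccc3c(c2)C(=O)CC(C2CCN(C(=O)OC(C)(C)C)CC2)O3)cc1` in a physicochemical assay for lipophilicity, at pH 7.4 (a lower number here means a more polar compound, a higher number a more lipophilic compound), gives 5.1
- compound 2 `CCc1ccc(N(CC(C)C)S(=O)(=O)c2ccc3c(c2)C(=O)CC(C2CCOCC2)O3)cc1` in this assay gives 4.21

For the measured compounds named here, only these two compounds have numbers so far. Compound 2 at 4.21 is the lower of the two, and compound 1 at 5.1 stands above it by more than the scatter. Compound 3 `CCc1ccc(N(CC(C)C)S(=O)(=O)c2ccc3c(c2)C(=O)CC(C2CCN(S(C)(=O)=O)CC2)O3)cc1` has not yet been measured. It carries 1-(methylsulfonyl)piperidin-4-yl in place of oxan-4-yl on a saturated ring carbon and is otherwise the same as compound 2. Going by the values given here, no measured pair shows the size of this particular change, so the expectation below is a judgement from the structural change and remains loosely anchored. A small upward move in this assay is expected, with no step beyond the scatter. The estimated a number 0.09 log units higher from compound 2 to compound 3 (within the scatter) is therefore minor, and the range is kept wide enough to allow a move in either direction. The expected value for compound 3 is 4.3 within an estimated range from 3.9 to 4.7 at its ends.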

Compound 3, distribution coefficient: 3.31
The estimate for compound 3 lay 0.99 log units above the measured number, outside the stated range (below it).
By their numbers in this assay, from the lowest: compound 3; then compound 2; then compound 1.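

At the saturated ring carbon next to the ring oxygen, 1-(methylsulfonyl)piperidin-4-yl in place of oxan-4-yl gives a number 0.90 log units lower from compound 2 to compound 3 (beyond the scatter) in this assay, so the entering group's 10 heavy atoms against the 6 of oxan-4-yl do not bring a higher number here. For the compounds shown here, on the amine nitrogen in a ring, methylsulfonyl in place of tert-butoxycarbonyl gives a number 1.79 log units lower from compound 1 to compound 3 (beyond the scatter), the first reading of a change at that nitrogen. The group on the ring nitrogen therefore sets where these piperidin-4-yl compounds fall relative to the oxan-4-yl compound: compound 1 stands above compound 2 and compound 3 stands below it.

Nothing in hand accounts for the size or direction of either step. Open, as far as these compounds go, is how an unsubstituted ring amine, an acetyl group or a longer alkylsulfonyl chain on that nitrogen would read in this assay, and whether these steps hold on other versions of the shared core.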